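A few compounds are considered here, and "the series" means these few. Any claim that something is new, unique, unknown or untested is made for them only; others in the source may bear on it.

Series notes. Compound 1 `S=c1[nH]nc(Nc2nc(-c3ccc(Br)cc3)cs2)n1-c1ccccc1` and compound 2 `S=c1[nH]nc(Nc2nc(-c3ccc(Cl)cc3)cs2)n1-c1ccccc1` share one core and differ only in that compound 2 carries chloro in place of bromo on an aromatic carbon. In a functional assay on the whole organism (strain Swiss albino) for inhibition, with Mus musculus as the target, with a stated time of 4 h (a lower number here means that less compound is needed, a higher number that more compound is needed for the effect), compound 1 gives 300 mg/kg. In this assay compound 2 gives 300 mg/kg. Among the measured compounds shown here, the one step measured so far, no change at the digits printed from compound 1 to compound 2 (within the scatter), leaves the minimum effective dose where it was, so compound 1 stands level with compound 2 and nothing in the numbers in hand separates the two.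

Compound 3 `Cc1ccccc1-n1c(Nc2nc(-c3ccc(Br)cc3)cs2)n[nH]c1=S` is the next compound to be measured. It differs from compound 1 by methyl in place of hydrogen on an aromatic carbon, that is, phenyl to 2-methylphenyl, on the ring that carries no halogen. For the measured compounds named here, no measured step touches this ring; the only step available, no change at the digits printed from compound 1 to compound 2 (within the scatter), concerns the other aromatic ring and shows no change. There is therefore no basis for expecting a move in this assay beyond the scatter in either direction, and the estimated step of no change at the digits printed from compound 1 to compound 3 (within the scatter) is set at no change. Compound 3 is expected to give 300 mg/kg in this assay, with a range from 150 mg/kg to 600 mg/kg.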

Compound 3, minimum effective dose: 30 mg/kg
Compound 3: middle estimate off by 10-fold (1.00 log units), on the high side, and the stated range ends above it.
By their numbers in this assay, from the lowest: compound 3; then compounds 1 and 2 (each within the scatter of the next).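

Changing phenyl to 2-methylphenyl, with methyl in place of hydrogen on an aromatic carbon ortho to a large group, gives a 10-fold lower number from compound 1 to compound 3 (1.00 log units; beyond the scatter) in this assay, whereas the halogen exchange on the other aromatic ring gave no change at the digits printed from compound 1 to compound 2 (within the scatter). Among the compounds shown here, this is the first sign that the minimum effective dose responds to a change at all, and the ring that carries no halogen is the place where it does, with a single added carbon enough to take the step beyond the scatter. No measurement at hand speaks to the reason for this step.

Methyl is the only group shown at this place, so it remains open whether an ethyl chain, a methoxy group or a chloro group there would lower the needed dose to the same degree. Also open, from the compounds shown here alone, is whether the step holds with chloro in place of bromo on the other aromatic ring, as the methyl is seen here only alongside bromo.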